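A Methyl Step Repeated on a Second Core

The source may hold more compounds than are shown below. What is called first, only, known or untested is meant among the compounds shown, and "the series" means these compounds.

Three compounds were tested in a functional assay on the whole organism (strain Wistar Albino) for inhibition, with Rattus norvegicus as the target, read by paw edema, with a stated time of 2 h, at a dose of 20 mg/kg; on this read-out higher numbers stand for more inhibition at the one dose given (going by the name of the read-out) and lower numbers for less inhibition. Compound 2 `Cc1occc1-c1nnc2sc(-c3ccnc4ccccc34)nn12` gives 17.1%. Compound 1 `Cc1cc(-c2nn3c(-c4ccoc4C)nnc3s2)c2ccccc2n1` gives 13.4% in this assay. Compound 3 `COc1ccc2[nH]cc(Cc3nn4c(Cc5ccc(OC)c(OC)c5)nnc4s3)c2c1` gives 11.6% in this assay, and its values lie within the usual scatter of both others, so no order among the three can be read from these numbers.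

Compound 2 and compound 1 differ in one place: methyl in place of hydrogen on an aromatic carbon. This produced a number 3.7 percentage points lower from compound 2 to compound 1 (within the scatter), a step that sits within the scatter of repeated measurements.

Compound 4 `COc1ccc2[nH]c(C)c(Cc3nn4c(Cc5ccc(OC)c(OC)c5)nnc4s3)c2c1` has not yet been measured. It is made from compound 3 by the same kind of change: methyl in place of hydrogen on an aromatic carbon. The surroundings differ, however. In compound 1 the methyl sits on a six-membered aromatic ring with 1 nitrogen, meta to a fused ring, meta to a large group and para to a fused ring; in compound 4 it sits on a five-membered aromatic ring with 1 nitrogen, next to the ring atom that bears a large group. The difference between the two cores of compound 2 and compound 3 is not broken down here.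

Because the earlier step was a number 3.7 percentage points lower from compound 2 to compound 1 (within the scatter), the step from compound 3 to compound 4 is expected to be similarly small, a number 0.4 percentage points higher from compound 3 to compound 4 (within the scatter). Compound 4 is therefore estimated at 12% in this assay, with a likely range from 4% to 22%.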

Compound 4, a percentage reported as inhibition, in the whole organism at one dose (the size of the read-out at that dose, not a potency): 16.2%
The estimate for compound 4 lay 4.2 percentage points below the measured number; the measured number falls inside the stated range.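

In this assay, methyl in place of hydrogen on an aromatic carbon, here on a five-membered aromatic ring with 1 nitrogen, gave a number 4.6 percentage points higher from compound 3 to compound 4 (within the scatter), so on this core too the step cannot be told apart from the ordinary spread of repeated measurements. The two steps carry opposite signs, but that gap gives no sign that the two cores respond differently: the same change on two cores in this assay, a number 3.7 percentage points lower (within the scatter) from compound 2 to compound 1 and a number 4.6 percentage points higher (within the scatter) from compound 3 to compound 4, 8.3 percentage points apart, within the scatter of two such steps. The change therefore carries from one core to the other with no measurable difference, which shows neither that methyl truly does nothing nor that both cores respond alike, since a small real effect could lie hidden in steps of this size.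

The compounds shown hold only hydrogen or methyl at the changed place, so it remains open whether a longer chain such as ethyl or propyl, an amine, or a carboxylic acid there would move the number beyond the scatter. Every reading also comes from a single dose and a single time, which leaves open how the compounds would compare in potency across a range of doses.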